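Fluoro to Trifluoromethyl on the Aromatic Group at the Carbonyl

A few compounds are considered here, and "the series" means these few. Any claim that something is new, unique, unknown or untested is made for them only; others in the source may bear on it.

Compound 1 `O=C(O)CC(NC(=O)c1ccc(F)cc1)c1ccc(Cl)cc1Cl`: 58300 nM
Compound 2 `O=C(O)CC(NC(=O)c1cccc(Br)c1)c1ccc(Cl)cc1Cl`: 82500 nM
Compound 3 `COc1ccccc1C(=O)NC(CC(=O)O)c1ccc(Cl)cc1Cl`: > 100000 nM (a limit of the assay, not a number)

In a functional assay on MDA-MB-231 cells (Homo sapiens) for antiproliferative activity, read by MTT assay, with a stated time of 24 h (a higher number here means a weaker inhibitor, a lower number a stronger inhibitor), compound 1 holds the lowest of the two numbers shown, with compound 2 nearest: a 1.4-fold higher number from compound 1 to compound 2 (0.15 log units; within the scatter). Compound 3 sits at the limit of > 100000 nM in this assay, at which 1 of the 3 values shown sits. Compound 4 `O=C(O)CC(NC(=O)c1ccc(C(F)(F)F)cc1)c1ccc(Cl)cc1Cl` changes only the substituent on the aromatic group at the carbonyl carbon: trifluoromethyl in place of fluoro on an aromatic carbon. Going by the values given here, the steps that bear on this are the other exchanges at that carbonyl carbon, a 1.4-fold higher number from compound 1 to compound 2 (0.15 log units; within the scatter) and an at least 1.7-fold higher number from compound 1 to compound 3 (0.23 log units; that floor lies within the scatter), neither of which reaches beyond the scatter, so no step beyond the scatter is expected here either. Compound 4 is therefore estimated at 65000 nM, within 25000 nM to 170000 nM. That estimate means an expected step of a 1.1-fold higher number from compound 1 to compound 4 (0.05 log units; within the scatter).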

Compound 4, half-maximal inhibitory concentration: 39100 nM
For compound 4 the middle estimate is 1.7-fold (0.22 log units) above the measured one; low and high end bracket the measured number.
By their numbers in this assay, from the lowest: compounds 4, 1 and 2 (each within the scatter of the next, the first and the last beyond it). At a limit, above all of these: compound 3.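

Trifluoromethyl brings 4 heavy atoms where fluoro had 1, and in this assay this exchange gives a 1.5-fold lower number from compound 1 to compound 4 (0.17 log units; within the scatter). A larger group on this aromatic carbon, para to a large group, therefore produces no step beyond the scatter, and the result stays a measured number. Compound 3 alone remains at a limit of the assay, not a number: the limit of > 100000 nM in this assay, at which 1 of the 4 values shown sits.

Still open, from the compounds shown here alone, is whether an amine or a carboxylic acid on this same carbon would move the number beyond the scatter. A longer chain there remains equally untested by the compounds shown.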